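Ethyl in place of hydrogen on the chain-end oxygen

A few compounds are considered here, and "the series" means these few. Any claim that something is new, unique, unknown or untested is made for them only; others in the source may bear on it.

Measured compounds in an ADME assay on HepG2 cells (Homo sapiens) for cytotoxicity, read by CellTiter-Glo and resazurin assay, with a stated time of 72 h; a higher number here means that more compound is needed for the effect, a lower number that less compound is needed:
Compound 1 `CC(C)Oc1cccc(-c2ccc(C(=O)N(Cc3cccc(OCCCCCC(=O)O)c3)C(C)C)cc2)c1` gives > 26000 nM, a limit of the assay.
Compound 2 `COc1cccc(-c2ccc(C(=O)N(Cc3cccc(OCCCCCC(=O)O)c3)C(C)C)cc2)c1` gives > 26000 nM, a limit of the assay.
Compound 3 `CC(C)N(Cc1cccc(OCCCCCC(=O)O)c1)C(=O)c1ccc(-c2ccc3cc[nH]c3c2)cc1` gives > 26000 nM, a limit of the assay.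

All three measured compounds stop at the limit of > 26000 nM in this assay, at which 3 of the 3 values shown sit. Compound 2 stands at that limit, and the two other values shown beside it are limits as well, so no numbered value places compound 2 relative to compound 1 or compound 3. The steps a step that the two limits leave unreadable from compound 1 to compound 2 and a step that the two limits leave unreadable from compound 2 to compound 3 are unreadable for the same reason, as is a step that the two limits leave unreadable from compound 1 to compound 3.

The unmeasured compound is compound 4 `CCOC(=O)CCCCCOc1cccc(CN(C(=O)c2ccc(-c3cccc(OC)c3)cc2)C(C)C)c1`. It differs from compound 2 by ethyl in place of hydrogen on an oxygen next to a carbonyl group. Read one bond further out, the change is hydroxy to ethoxy, or carboxy to ethoxycarbonyl, on the chain that hangs from the oxygen of the aromatic ring. Within the data shown here, none of the measured steps touches this end of the chain, and none of them yields a readable size. Among the measured compounds shown here, what the data offer is only that every compound measured so far sits at the limit. The expectation for this assay therefore rests on that alone: no step beyond the scatter is expected, and the estimated step is a number no higher from compound 2 to compound 4 (the limit leaves the size open). Compound 4 is expected to give about 26000 nM, within 9000 nM to 60000 nM, with a fair chance that the assay again reports only a limit.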

Compound 4, half-maximal effective concentration: > 21000 nM
Compound 4 ended at the assay's limit (the forecaster's own chance of this, stated with the estimate: 65%); the middle value is on the limit's open side.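

Compound 2 and compound 4 both stop at limits of the assay, so the step between them cannot be read. The compounds shown leave open where any of them would reach its half-maximal effect in this assay, and whether ethyl in place of hydrogen on the oxygen changes that concentration at all.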